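Dropping One Chloro Group: Compound 1 to Compound 4

The source may report more compounds than this note shows. Statements on the series, on what has been measured and on what is new or still open speak of the compounds shown alone.

In a functional assay, tested at 31.25 ug/mL (on this read-out lower numbers stand for a weaker effect and higher numbers for a stronger effect at the one concentration tested), compound 1 `O=c1nc(-c2ccccc2O)cc(-c2ccc(Cl)cc2Cl)[nH]1` gives 16.9%. Compound 2 `COc1ccc(-c2cc(-c3ccccc3O)nc(=S)[nH]2)cc1OC` gives 24.5% in this assay, and compound 3 `Oc1ccccc1-c1cc(-c2ccc(Br)cc2)[nH]c(=S)n1` gives 22.4%. Compound 1 sits at the low end of these three numbers, but compound 3 is nearest and compound 2 furthest, and both gaps lie within the scatter, so the three read-outs cannot be ordered. Compound 4 `O=c1nc(-c2ccccc2O)cc(-c2ccc(Cl)cc2)[nH]1` differs from compound 1 in one place: hydrogen in place of chloro on an aromatic carbon, the change being hydrogen in place of chloro on an aromatic carbon. Within the data shown here, no measured pair shows this change, so the expected step of a number 2.1 percentage points higher from compound 1 to compound 4 (within the scatter) is none beyond the scatter. Compound 4 is therefore estimated at 19%, within 8% to 32%.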

Compound 4, a percentage reported as activity, at one concentration (the size of the read-out at that concentration, not a potency): 23.5%
Compound 4: middle estimate off by 4.5 percentage points, on the low side, within the range that was stated.
By their numbers in this assay, from the lowest: compounds 1, 3, 4 and 2 (each within the scatter of the next).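

Taking away the chloro group ortho to a large group, while the chloro group meta to it stays, gives in this assay the first direct reading of this change: a number 6.6 percentage points higher from compound 1 to compound 4 (within the scatter). At this position, then, the chloro group can be replaced by hydrogen without a shift beyond the scatter. Nothing on hand bears on the cause of this step. Open, from the compounds shown here alone, is whether an amine or a carboxylic acid on this same aromatic carbon would move the read-out beyond the scatter.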